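Anilino variation at the shared core: toward an indolyl analogue

The source may hold more compounds than are shown below. What is called first, only, known or untested is meant among the compounds shown, and "the series" means these compounds.

Measured compounds:
compound 1, `Cc1ccc(S(=O)(=O)c2cc3cnc(Nc4cccc5cccnc45)nc3n(C)c2=O)cc1` — 10000 nM
compound 2, `COc1ccc(Nc2ncc3cc(S(=O)(=O)c4ccc(C)cc4)c(=O)n(C)c3n2)cc1` — 100000 nM

Both numbers come from a functional assay on DU-145 cells (Homo sapiens) for inhibition, read by trypan blue exclusion, with a stated time of 72 h; on this read-out lower numbers stand for stronger inhibition and higher numbers for weaker inhibition. Compound 1 gives 10000 nM, and compound 2 gives 100000 nM; compound 2 therefore stands with the higher of the two numbers, and its nearest neighbour is compound 1. Among the measured compounds shown here, the one measured step, a 10-fold higher number from compound 1 to compound 2 (1.00 log units; beyond the scatter), is the only comparison available and concerns the same position on the nitrogen on an aromatic ring that is varied next.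

Compound 3, `Cc1ccc(S(=O)(=O)c2cc3cnc(Nc4cccc5[nH]ccc45)nc3n(C)c2=O)cc1`, is not yet measured. It differs from compound 2 by 1H-indol-4-yl in place of 4-methoxyphenyl on a nitrogen on an aromatic ring. Like the group in compound 1, the entering 1H-indol-4-yl is bicyclic, whereas the leaving 4-methoxyphenyl of compound 2 is a single ring. The step from compound 1 to compound 2 is the relevant precedent: it ran in the direction of weaker inhibition when the bicyclic group was replaced, so the reverse kind of change is expected to move the number in this assay back down, by roughly a 6.7-fold lower number from compound 2 to compound 3 (0.82 log units; beyond the scatter). Compound 3 is thus estimated at 15000 nM, with a range of 4000 nM to 60000 nM.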

Compound 3, half-maximal inhibitory concentration: 10000 nM
Compound 3: middle estimate off by 1.5-fold (0.18 log units), on the high side; the measured number falls inside the stated range.
By their numbers in this assay, from the lowest: compounds 1 and 3 (each within the scatter of the next); then compound 2.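

In this assay, a second bicyclic group on the nitrogen on an aromatic ring gives a 10-fold lower number from compound 2 to compound 3 (1.00 log units; beyond the scatter), so the earlier gap between quinolin-8-yl and 4-methoxyphenyl is not peculiar to quinolin-8-yl: across these compounds, both bicyclic groups carry lower numbers than the single ring, and no compound shown goes against this. The two bicyclic groups themselves are not told apart, with no change at the digits printed from compound 1 to compound 3 (within the scatter), even though 1H-indol-4-yl brings a five-membered aromatic ring and a hydrogen-bond donor; at this level of inhibition, the read-out does not separate these two ring systems. No measurement on hand bears on why this position responds as it does.

The compounds shown leave open whether the higher number of compound 2 goes with having a single ring or with its methoxy group, a question that plain phenyl or 4-hydroxyphenyl at the same place would address. Also open, on these data alone, is whether any group on this nitrogen can bring the number well below the level shared by compound 1 and compound 3, for instance a phenyl ring carrying a piperazine or a longer aminoalkyl chain.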